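Replacing a benzylamino group with an arylthio group

The compounds below may be only part of what the source reports. "The series", "measured", "known", "first", "only" and "open" are said of these compounds alone.

Compound 1 `COc1ccc(CNc2nc3cc(N)cc(N)c3nc2-c2ccccc2)cc1OC` gives 21900 nM in a functional assay on SK-OV-3 cells (Homo sapiens) for inhibition, read by sulforhodamine B assay, with a stated time of 48 h; a higher number here means a weaker inhibitor of growth, a lower number a stronger inhibitor of growth.
Compound 2 `Nc1cc(N)c2nc(-c3ccccc3)c(NCc3ccc(F)cc3)nc2c1` gives 12900 nM in this assay.

Compound 2 stands nearest compound 1, and the step of a 1.7-fold lower number from compound 1 to compound 2 (0.23 log units; within the scatter) lies within the scatter, so the two are not distinguished. Compound 3 `Nc1cc(N)c2nc(-c3ccccc3)c(Sc3ccc(Cl)c(Cl)c3)nc2c1` carries the change ((3,4-dichlorophenyl)sulfanyl in place of (4-fluorobenzyl)amino on an aromatic carbon). Within the data shown here, the only measured step alters the group on the saturated chain carbon while keeping the amino link; no measured step exchanges that link, so nothing bears directly on this change. The estimate for compound 3 is therefore placed near compound 2, with a wide range, as a step of a 1.6-fold higher number from compound 2 to compound 3 (0.19 log units; within the scatter), giving 20000 nM between 5000 nM and 80000 nM.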

Compound 3, concentration for 50% growth inhibition: 14800 nM
For compound 3 the middle estimate is 1.4-fold (0.13 log units) above the measured one, within the range that was stated.
By their numbers in this assay, from the lowest: compounds 2, 3 and 1 (each within the scatter of the next).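

In this assay the exchange of (4-fluorobenzyl)amino for (3,4-dichlorophenyl)sulfanyl on this aromatic carbon gives a 1.1-fold higher number from compound 2 to compound 3 (0.06 log units; within the scatter) and leaves compound 3 not distinguished from compound 2. The amino link and its hydrogen-bond donor, kept in both earlier compounds, can therefore be replaced here without a step beyond the scatter. Nothing given here explains this result.

From the compounds shown here alone, the link and the ring substituents change together in this step, so their separate shares stay open. Also open, going by these compounds, is what an oxygen link or a piperazine on this carbon would give.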